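Replacing naphthalen-1-yl with 4-fluorophenyl on the shared core

The compounds below may be only part of what the source reports. "The series", "measured", "known", "first", "only" and "open" are said of these compounds alone.

Three compounds of the series have numbers in a functional assay on MDA-MB-231 cells (Homo sapiens) for inhibition, read by sulforhodamine B assay, with a stated time of 48 h, tested at 10 uM; a lower number here means less inhibition, a higher number more inhibition at the concentration tested (going by the name of the read-out). Compound 1 `Brc1cn2ccnc2c(-c2ccc3ncn(C4CCCCC4)c3c2)n1` gives 24.2%, compound 2 `COc1ccc(-c2cn3ccnc3c(-c3ccc4ncn(C5CCCCC5)c4c3)n2)cc1` gives 71.1% and compound 3 `c1ccc2c(-c3cn4ccnc4c(-c4ccc5ncn(C6CCCCC6)c5c4)n3)cccc2c1` gives 20.8%. Compound 3 carries the lowest number of the three; the gap to compound 1 is within the scatter, while the gap to compound 2 is the only large one: a number 50.3 percentage points lower from compound 2 to compound 3 (beyond the scatter). The move from compound 1 to compound 3 was a number 3.4 percentage points lower from compound 1 to compound 3 (within the scatter), whereas a number 46.9 percentage points higher from compound 1 to compound 2 (beyond the scatter).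

Compound 4 `Fc1ccc(-c2cn3ccnc3c(-c3ccc4ncn(C5CCCCC5)c4c3)n2)cc1` is not yet measured. It differs from compound 3 in one place: 4-fluorophenyl in place of naphthalen-1-yl on an aromatic carbon. Going by the values given here, the step that bears on this is the one from compound 2 to compound 3, which removed a 4-methoxyphenyl in favour of naphthalen-1-yl and lost a large amount. Compound 4 puts a single six-membered ring back in the same place, though with fluorine rather than methoxy, and the series holds no 4-fluorophenyl for comparison. Because compound 2 reached 71.1%, a step back upward is expected, estimated as a number 29.2 percentage points higher from compound 3 to compound 4 (beyond the scatter). Compound 4 is thus expected to give about 50% in this assay, within a range from 25% to 75%.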

Compound 4, a percentage reported as inhibition, at one concentration (the size of the read-out at that concentration, not a potency): 15.8%
Compound 4: middle estimate off by 34.2 percentage points, on the high side, and the stated range ends above it.
By their numbers in this assay, from the lowest: compounds 4, 3 and 1 (each within the scatter of the next); then compound 2.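

In this assay, putting a single six-membered aromatic ring back at this position does not restore the high number of compound 2: the change reads a number 5 percentage points lower from compound 3 to compound 4 (within the scatter) and, against the bromo compound, a number 8.4 percentage points lower from compound 1 to compound 4 (within the scatter). The substituent on that ring is what counts here, since fluoro in place of methoxy gives a number 55.3 percentage points lower from compound 2 to compound 4 (beyond the scatter), leaving 4-methoxyphenyl alone apart from bromo, naphthalen-1-yl and 4-fluorophenyl. Nothing shown here explains why methoxy and fluoro differ so widely.

Open, from the compounds shown here alone, is whether the high number is specific to methoxy or is shared by other groups on the same ring, such as a hydroxy group, an amine or a longer alkoxy chain. Going by these compounds alone, with one concentration per compound, these numbers also give no potency for any compound.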